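This account rests on a few compounds, and the source may have more. Where it says the series, first, only, none or still open, it means among the compounds named here.

- compound 1 `O[C@@]1(c2ccccn2)CC[C@@H](c2ccc(C(F)(F)F)cc2)C1` gives 2520 mL/min/kg
- compound 2 `O[C@H](c1ccccn1)[C@]1(c2cccc(OC(F)(F)F)c2)C[C@H](O)C1` gives 117 mL/min/kg
- compound 3 `OC(c1ccccn1)C1(c2ccc(C(F)(F)F)cc2)CNC1` gives 50 mL/min/kg

These three numbers come from an ADME assay on liver for metabolic stability, with Liver microsome (Rattus norvegicus) as the target, read by LC-MS, using microsomes, with a stated time of 5 h (a lower number here means slower removal, a higher number faster removal of the compound), and span a wide range. Compound 1 stands highest of the three (2520 mL/min/kg), and compound 2 and compound 3 both lie lower, by gaps beyond the scatter. Those two compounds differ from compound 1 in several places at once, so they say little about any single change.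

Compound 4 (`O[C@]1(c2ccccn2)CC[C@H](c2ccc(C(F)(F)F)cc2)C1`) has not been measured yet. Its difference from compound 1 is purely one of shape in space (the two compounds have the same atoms and bonds and differ only in configuration as drawn: 2 of 2 stereo elements differ (all stereocentres are inverted: mirror images); a stereocentre at a saturated ring carbon is drawn S in compound 1 and R in compound 4; a stereocentre at a saturated ring carbon is drawn R in compound 1 and S in compound 4). The two have the same atoms and bonds, and all stereocentres are inverted, which makes them mirror images.

Within the data shown here, none of the measured compounds forms such a mirror-image pair, so the data do not show how large this step can be in this assay. The expectation is therefore no step beyond the scatter, with only a slight lean towards a lower number because compound 1 (2520 mL/min/kg) sits at the top of the measured values. The estimated step is small (a 1.4-fold lower number from compound 1 to compound 4 (0.15 log units; within the scatter)) and stays within the scatter. Compound 4 is expected near 1800 mL/min/kg, with an estimated range from 600 mL/min/kg to 4500 mL/min/kg.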

Compound 4, clearance: 1430 mL/min/kg
Compound 4: middle estimate off by 1.3-fold (0.10 log units), on the high side, within the range that was stated.
By their numbers in this assay, from the lowest: compound 3; then compound 2; then compounds 4 and 1 (each within the scatter of the next).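

In this assay, turning the molecule into its mirror image gives a 1.8-fold lower number from compound 1 to compound 4 (0.25 log units; within the scatter), so this pair offers no sign that the handedness of the shared core changes how fast it is removed. Among these compounds, this is the first comparison here that isolates a single change, since the earlier compounds differed in several places at once and their wide spread could not be tied to any one of them. It is also a clean test, with only one thing separating the two structures: the fact that compounds 1 and 4 differ only in the configuration as drawn. The very fast removal is therefore not confined to one mirror form, as compound 4 still gives 1430 mL/min/kg.

The compounds shown leave open what happens when only one of the two stereocentres is inverted, a change that gives a different shape rather than a mirror image. They also leave open which part of the core matters for this fast removal, and whether replacing the trifluoromethyl group with a nitrile or a carboxylic acid would move the number beyond the scatter.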